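A Saturated Amide Replaces a Chlorothiophene

The source may hold more compounds than are shown below. What is called first, only, known or untested is meant among the compounds shown, and "the series" means these compounds.

Compound 1 (`O=S(=O)(Nc1ccc(-c2nc3cc(NS(=O)(=O)c4ccccc4)ccc3o2)cc1)c1ccccc1`) value 16000 nM
Compound 2 (`COc1ccc(S(=O)(=O)Nc2ccc3oc(-c4ccc(NC(=O)c5ccc(Cl)s5)cc4)nc3c2)cc1`) value 4600 nM

In a functional assay on DLD-1 cells (Homo sapiens) for cytotoxicity, read by resazurin assay, with a stated time of 48 h (on this read-out higher numbers stand for an effect only at larger amounts of compound and lower numbers for an effect already at smaller amounts), compound 2 gives 4600 nM and so holds the lower of the two numbers, with a gap to compound 1 that lies beyond the scatter. These two compounds differ in more than one place, so their gap cannot be tied to any single group.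

Compound 3 (`COc1ccc(S(=O)(=O)Nc2ccc3oc(-c4ccc(NC(=O)C5CCN(C(C)=O)CC5)cc4)nc3c2)cc1`) has not been measured yet. It departs from compound 2 in one place (1-acetylpiperidin-4-yl in place of 5-chlorothiophen-2-yl on a carbonyl carbon): 1-acetylpiperidin-4-yl sits in place of 5-chlorothiophen-2-yl on a carbonyl carbon. Among the compounds with values here, no measured pair shows this exchange directly, so any forecast remains soft. Within the data shown here, the only hint is that compound 1, which lacks the 5-chlorothiophen-2-yl, gives 16000 nM as the higher number. A move towards a higher number is therefore expected, meaning that a larger amount of compound would be needed for the effect. In this assay the estimated step is a 2.6-fold higher number from compound 2 to compound 3 (0.42 log units; beyond the scatter) and would lie beyond the scatter. The estimate for compound 3 is 12000 nM (expected range 4500 nM to 35000 nM).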

Compound 3, half-maximal effective concentration: 15000 nM
Compound 3: the middle estimate sits 1.3-fold (0.10 log units) below what was measured; the measured number falls inside the stated range.
By their numbers in this assay, from the lowest: compound 2; then compounds 3 and 1 (each within the scatter of the next).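

In this assay, within the data shown here, the exchange of 5-chlorothiophen-2-yl for 1-acetylpiperidin-4-yl on a carbonyl carbon gives a 3.3-fold higher number from compound 2 to compound 3 (0.51 log units; beyond the scatter) and is the first gap here that can be tied to a single place, since the earlier pair differed in more than one. It shows that what sits on this carbonyl matters in this assay: with the rest of the molecule unchanged, replacing a five-membered aromatic ring with a six-membered non-aromatic ring bearing an acetyl group means that a larger amount of compound is needed for the effect. No available measurement explains why this exchange has that effect.

This single exchange changes the ring, removes the chlorine and sulfur, and adds the acetyl group all at once, so the compounds shown cannot separate the contribution of each part. An unsubstituted thiophene would test the chlorine alone, a phenyl ring would test the sulfur-containing ring, and a piperidine with a free amine would test the acetyl group, leaving open which of these parts governs the step.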